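A few compounds are considered here, and "the series" means these few. Any claim that something is new, unique, unknown or untested is made for them only; others in the source may bear on it.

Going by the values given here, three compounds share one core, a cyclic urea carrying an aromatic ring, and differ only in the single group on that ring. In an assay on RBL-1 cells for inhibition of Polyunsaturated fatty acid 5-lipoxygenase (Rattus norvegicus) (a higher number here means a weaker inhibitor, a lower number a stronger inhibitor), compound 1 `Cc1ccccc1N1CCNC(=O)N1` gives 386000 nM. Compound 2 `CCc1cccc(N2CCNC(=O)N2)c1` gives 13000 nM in this assay, and compound 3 `O=C1NCCN(c2cccc(F)c2)N1` gives 19000 nM. Among these three numbers compound 3 stands second highest: its value sits close to that of compound 2, within the scatter, while the value of compound 1 lies far higher, well beyond the scatter.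

Among the compounds with values here, only one measured step changes a single group on the ring: a 1.5-fold higher number from compound 2 to compound 3 (0.16 log units; within the scatter). Compound 4 `COc1cccc(N2CCNC(=O)N2)c1` takes the next step of that kind, (methoxy in place of fluoro on an aromatic carbon). Within the data shown here, the one step that bears on it, the exchange of ethyl for fluoro at the same place, left the number essentially unchanged. Among the measured compounds shown here, no measured compound carries a methoxy group, so the new substituent itself is untested here. On that basis the step from compound 3 to compound 4 is expected to be small, with no clear direction, most likely inside the scatter: an expected step of a 1.1-fold higher number from compound 3 to compound 4 (0.02 log units; within the scatter). For compound 4 the estimated value in this assay is 20000 nM, with a range from 6000 nM to 65000 nM.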

Compound 4, half-maximal inhibitory concentration: 47000 nM
Compound 4: middle estimate off by 2.4-fold (0.37 log units), on the low side; the range from low to high includes it.
By their numbers in this assay, from the lowest: compounds 2 and 3 (each within the scatter of the next); then compound 4; then compound 1.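

In this assay, the aromatic carbon that carries these groups is not indifferent to what sits there: a 2.5-fold higher number from compound 3 to compound 4 (0.39 log units; beyond the scatter), and a 3.6-fold higher number from compound 2 to compound 4 (0.56 log units; beyond the scatter), so methoxy stands apart from both fluoro and ethyl, which lie within the scatter of each other. Both steps are modest, and with a single methoxy compound the data cannot separate the roles of what this change adds, namely one more heavy atom and one hydrogen-bond acceptor. Nothing available here gives a measured reason for the higher number of compound 4.

Going by these compounds alone, only three groups can be compared at this place on the aromatic ring, so it remains open whether a hydroxyl group, an amine, a carboxylic acid or a longer ether chain such as ethoxy would group with methoxy or with fluoro and ethyl. From the compounds shown here alone, it is also open whether methoxy would give a step of similar size and direction on a different carbon of the same ring.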